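The source may report more compounds than this note shows. Statements on the series, on what has been measured and on what is new or still open speak of the compounds shown alone.

Measured so far:
compound 1, `COc1cc2c(cc1OC)C(CC(=O)O)CC2`: 24%
compound 2, `COc1cc2c(cc1OC)C(CC(=O)Nc1ccccc1)CC2`: 32%

Both were tested in a functional assay on the whole organism (strain Wistar) for inhibition, with Rattus norvegicus as the target, read by paw edema, with a stated time of 2 h, at a dose of 100 mg/kg; on this read-out lower numbers stand for less inhibition and higher numbers for more inhibition at the one dose given (going by the name of the read-out). Compound 2 stands highest of the two numbers shown, but its only neighbour, compound 1, lies within the scatter of it, so the two cannot be ranked against each other. For the measured compounds named here, the single measured step, a number 8 percentage points higher from compound 1 to compound 2 (within the scatter), put anilino in place of hydroxy on the carbonyl carbon and moved the read-out by less than the usual scatter.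

Compound 3, `COc1cc2c(cc1OC)C(CC(=O)Nc1cccnc1)CC2`, has not yet been measured. It differs from compound 2 in one place: pyridin-3-yl in place of phenyl on an amide-type nitrogen. The six-membered aromatic ring on the amide-type nitrogen stays, now carrying one hetero atom and one hydrogen-bond acceptor.

Going by the values given here, no measured step tries this exchange. Among the compounds with values here, the only step known concerns the amide end, not the ring on it, so it gives no direct guide, and nothing in the numbers points up or down. The step of no change at the digits printed from compound 2 to compound 3 (within the scatter) is therefore expected to lie within the scatter. Compound 3 is estimated at 32%, between 15% and 50%.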

Compound 3, a percentage reported as inhibition, in the whole organism at one dose (the size of the read-out at that dose, not a potency): 30%
Compound 3: middle estimate off by 2 percentage points, on the high side, within the range that was stated.
By their numbers in this assay, from the lowest: compounds 1, 3 and 2 (each within the scatter of the next).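

In this assay, putting pyridin-3-yl in place of phenyl on the amide-type nitrogen adds a ring nitrogen and a hydrogen-bond acceptor, and the exchange gives a number 2 percentage points lower from compound 2 to compound 3 (within the scatter). At this one dose, then, compound 2 and compound 3 cannot be told apart, so this first test of the ring itself shows that the phenyl can give way to pyridin-3-yl without a readable difference. The second step, (pyridin-3-yl)amino in place of hydroxy on the carbonyl carbon, gives a number 6 percentage points higher from compound 1 to compound 3 (within the scatter), so this amide cannot be separated from the acid either, and no other data here speak to what lies behind these numbers.

Open, from the compounds shown here alone, is whether a different kind of group on the amide-type nitrogen, such as a benzyl or cyclohexyl group, or a phenyl carrying a chlorine or a methoxy group, would give a number clearly apart from these. Also open, going by these compounds, is how the three compounds would compare at other doses or at other times, since a reading at a single dose shows the size of the effect there and not a potency.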